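Two cores, one substituent swap: notes on compound 4

The source may report more compounds than this note shows. Statements on the series, on what has been measured and on what is new or still open speak of the compounds shown alone.

Measured so far:
compound 1 `COc1cccc2sc(NC(=O)c3ccc(C(F)(F)F)cc3)nc12`: > 10 ug/mL
compound 2 `COc1cccc2sc(NC(=O)c3ccc(C#N)cc3)nc12`: > 10 ug/mL
compound 3 `COc1ccc2sc(NC(=O)c3ccc(C(F)(F)F)cc3)nc2c1`: > 10 ug/mL

In a functional assay on NUGC-3 cells (Homo sapiens) for antiproliferative activity, read by sulforhodamine B assay (on this read-out higher numbers stand for weaker inhibition of growth and lower numbers for stronger inhibition of growth), compound 1 reaches only a limit, > 10 ug/mL. Compound 2 also gives only a limit in this assay, > 10 ug/mL. The change between them is cyano in place of trifluoromethyl on an aromatic carbon; the step that the two limits leave unreadable from compound 1 to compound 2 has no readable size because of the limit of > 10 ug/mL in this assay, at which 3 of the 3 values shown sit. Compound 3 likewise gives only a limit, > 10 ug/mL. The difference between the core of compound 1 and the core of compound 3 is not broken down here.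

Compound 4 `COc1ccc2sc(NC(=O)c3ccc(C#N)cc3)nc2c1` is not yet measured; it differs from compound 3 by cyano in place of trifluoromethyl on an aromatic carbon, the same change as that from compound 1 to compound 2. Compound 4 is expected to sit at the limit as well, estimated at 15 ug/mL, an expected step that the limit leaves unreadable from compound 3 to compound 4, because of the limit of > 10 ug/mL in this assay, at which 3 of the 3 values shown sit.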

Compound 4, concentration for 50% growth inhibition: > 10 ug/mL
Compound 4 was reported as a limit; the forecaster's own chance of this, stated with the estimate: 85%; the middle value does not contradict the limit.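

Compound 3 and compound 4 both give only limits in this assay, so no size can be read for the step between them: the limit of > 10 ug/mL in this assay, at which 4 of the 4 values shown sit.

On these data alone, whether cyano in place of trifluoromethyl changes growth inhibition on either core, and whether the two cores differ at all, stays open.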